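Methoxy for (4-fluorobenzyl)amino on the carbonyl carbon

The source may report more compounds than this note shows. Statements on the series, on what has been measured and on what is new or still open speak of the compounds shown alone.

For the measured compounds named here, in a functional assay on MCF7 cells (Homo sapiens) for cytotoxicity, read by MTT assay, with a stated time of 72 h (a lower number here means a stronger inhibitor, a higher number a weaker inhibitor), compound 1 `N[C@H]1CC[C@H](Nc2c(C(=O)NCc3ccc(F)cc3)nc(Br)c3cccnc23)CC1` gives 2000 nM, the lowest of the three numbers so far. Compound 2 `N[C@H]1CC[C@H](Nc2c(C(=O)NCc3ccc(F)cc3)nc(N3CCCCC3)c3cccnc23)CC1` gives 5000 nM, and compound 3 `CN(C)c1ccc(CNC(=O)c2nc(Br)c3cccnc3c2N[C@H]2CC[C@H](N)CC2)cc1` gives 5000 nM.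

Compound 4 `COC(=O)c1nc(Br)c2cccnc2c1N[C@H]1CC[C@H](N)CC1` is not yet measured. Its difference from the reference is methoxy in place of (4-fluorobenzyl)amino on a carbonyl carbon.

Two measured steps offer guidance, and neither removes that whole group. The closer one, a 2.5-fold higher number from compound 1 to compound 3 (0.40 log units; beyond the scatter), is modest and puts dimethylamino in place of fluoro on an aromatic carbon within the departing group. The other, a 2.5-fold higher number from compound 1 to compound 2 (0.40 log units; beyond the scatter), is equally modest but replaces bromo, so it bears only on how far single changes have moved this series. Going by the values given here, no measured compound shows the effect of the full replacement, so the direction rests on compound 3 alone, with its step of a 2.5-fold higher number from compound 1 to compound 3 (0.40 log units; beyond the scatter) towards a higher number.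

The expected change is a 3.0-fold higher number from compound 1 to compound 4 (0.48 log units; beyond the scatter), similar to or somewhat larger than the measured steps. For compound 4 the estimated value is 6000 nM, with an expected range of 2000 nM to 20000 nM.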

Compound 4, half-maximal inhibitory concentration: > 20000 nM
Compound 4: only a limit was reported (the forecaster's own chance of this, stated with the estimate: 15%); at least 3.3-fold (0.52 log units) between middle value and limit.
By their numbers in this assay, from the lowest: compound 1; then compounds 2 and 3 (each within the scatter of the next). At a limit, above all of these: compound 4.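

In this assay, replacing the whole (4-fluorobenzyl)amino group on the carbonyl carbon with methoxy gives an at least 10-fold higher number from compound 1 to compound 4 (1.00 log units; beyond the scatter), whereas the change within that group gave only a 2.5-fold higher number from compound 1 to compound 3 (0.40 log units; beyond the scatter). The series therefore tolerates a substitution on the aromatic ring of this group better than the loss of the entire group, on the evidence of these two steps alone. Compound 4 is reported only as a limit, so the true size of its step remains unfixed: the limit of > 20000 nM in this assay, at which 1 of the 4 values shown sits.

The compounds shown do not separate the loss of the aromatic ring from the loss of the amide hydrogen; a benzyl ester and a simple methylamide on the carbonyl carbon would address these two changes separately. Also open, going by these compounds, is whether a carboxylic acid or a longer-chain amine at this place would fall as far as methoxy.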